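Sulfonamide nitrogen groups: from compound 3 to compound 4

This account rests on a few compounds, and the source may have more. Where it says the series, first, only, none or still open, it means among the compounds named here.

Measured so far in a functional assay on MCF7 cells (Homo sapiens) for antiproliferative activity, read by MTT assay, with a stated time of 72 h (a higher number here means a weaker inhibitor, a lower number a stronger inhibitor), with these results
- compound 1 `Cc1cccc(N(C)S(=O)(=O)C2CC3OC2C(c2ccc(NC(=O)CCCCCCC(=O)O)cc2)=C3c2ccc(O)cc2)c1` gives 30200 nM
- compound 2 `COc1cccc(N(C)S(=O)(=O)C2CC3OC2C(c2ccc(NC(=O)CCCCCCC(=O)O)cc2)=C3c2ccc(O)cc2)c1` gives 39400 nM
- compound 3 `CN(c1cccc2ccccc12)S(=O)(=O)C1CC2OC1C(c1ccc(NC(=O)CCCCCCC(=O)O)cc1)=C2c1ccc(O)cc1` gives 14000 nM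

Compound 3 holds the lowest of the three numbers (14000 nM), and its gaps to both others lie beyond the scatter. Compound 4 `CCN(c1cccc(C)c1)S(=O)(=O)C1CC2OC1C(c1ccc(NC(=O)CCCCCCC(=O)O)cc1)=C2c1ccc(O)cc1` carries ethyl(3-methylphenyl)amino in place of methyl(naphthalen-1-yl)amino on a sulfonyl sulfur. The nearest measured evidence is the naphthalen-1-yl for 3-methylphenyl step (a 2.2-fold lower number from compound 1 to compound 3 (0.33 log units; beyond the scatter)), which would be run in reverse here. The methoxy for methyl step (a 1.3-fold higher number from compound 1 to compound 2 (0.12 log units; within the scatter)) stays within the scatter and bears less. Among the compounds with values here, no measured step covers ethyl for methyl on the sulfonamide nitrogen, so a modest rise is expected in this assay. For compound 4 the expected step is a 2.0-fold higher number from compound 3 to compound 4 (0.30 log units; within the scatter) (an estimate). Compound 4 is estimated at 28000 nM (expected range 14000 nM to 56000 nM).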

Compound 4, half-maximal inhibitory concentration: 31800 nM
Compound 4: the middle estimate sits 1.1-fold (0.06 log units) below what was measured, and the stated range covers the measured number.
By their numbers in this assay, from the lowest: compound 3; then compounds 1, 4 and 2 (each within the scatter of the next).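

Against this assay, the methyl added on the saturated chain carbon bound to the sulfonamide nitrogen gives a 1.1-fold higher number from compound 1 to compound 4 (0.02 log units; within the scatter) and so shifts the number by no more than the scatter. The exchange of the 3-methoxyphenyl group and methyl for 3-methylphenyl and ethyl likewise gives only a 1.2-fold lower number from compound 2 to compound 4 (0.09 log units; within the scatter) here, whereas the combined change of both nitrogen groups gives a 2.3-fold higher number from compound 3 to compound 4 (0.36 log units; beyond the scatter) and keeps the naphthalen-1-yl compound apart from the other three. No measurement on hand explains these steps.

Open, as far as these compounds go, is whether ethyl paired with naphthalen-1-yl would hold that lower number. Also open, from the compounds shown here alone, is how a propyl or benzyl group on this nitrogen would read.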